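A few compounds are considered here, and "the series" means these few. Any claim that something is new, unique, unknown or untested is made for them only; others in the source may bear on it.

Measured in an ADME assay (liver) for metabolic stability, with Liver microsome (Homo sapiens) as the target, using microsomes; on this read-out higher numbers stand for a longer-lived compound and lower numbers for a shorter-lived compound:
- compound 1 `CCc1nc2cc(Cl)ccn2c1C(=O)NCc1ccc(-c2ccc(Cl)cc2)cc1`: > 2 h
- compound 2 `CCc1nc2cc(Cl)ccn2c1C(=O)NCc1ccc(-c2ccc(C(=O)O)cc2)cc1`: > 2 h
- compound 3 `CCc1nc2cc(Cl)ccn2c1C(=O)NCc1ccc(-c2ccc[nH]2)cc1`: > 2 h

Each of these readings is a limit of the assay, not a number. Compound 3 therefore stands only at its limit (> 2 h). All three compounds share that one reading (the limit of > 2 h in this assay, at which 3 of the 3 values shown sit).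

The next compound, compound 4 `CCc1nc2cc(Cl)ccn2c1C(=O)NCc1ccc(-c2ccncc2)cc1`, carries pyridin-4-yl in place of 1H-pyrrol-2-yl on an aromatic carbon, para to a large group (pyridin-4-yl in place of 1H-pyrrol-2-yl on an aromatic carbon). Two measured steps change the group at this same place: a step that the two limits leave unreadable from compound 1 to compound 3 and a step that the two limits leave unreadable from compound 2 to compound 3. The third, a step that the two limits leave unreadable from compound 1 to compound 2, swaps chloro for carboxy and bears on the change less directly. None of the three has a readable size, so they offer no direction and no magnitude. No change beyond the scatter is therefore expected in this assay. The expected change is a step that the limit leaves unreadable from compound 3 to compound 4 on this estimate. For compound 4 the estimated half-life is 2.5 h (expected range 1.2 h to 6 h).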

Compound 4, half-life: 0.482 h
Beside the measured number, compound 4's estimate is 5.2-fold (0.71 log units) above it; measured number outside the range, below it.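

In this assay, the group on this aromatic carbon, para to a large group, now has a readable effect: an at least 4.1-fold lower number from compound 3 to compound 4 (0.61 log units; beyond the scatter), alongside an at least 4.1-fold lower number from compound 2 to compound 4 (0.61 log units; beyond the scatter) and an at least 4.1-fold lower number from compound 1 to compound 4 (0.61 log units; beyond the scatter). The steps among compounds 1, 2 and 3 cannot be read, so none of them showed that a change at this place could move the half-life. Pyridin-4-yl is the only group shown that gives a number rather than a limit, while 4-chlorophenyl, 4-carboxyphenyl and 1H-pyrrol-2-yl share one reading: the limit of > 2 h in this assay, at which 3 of the 4 values shown sit.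

On these data alone, the full size of each new step remains open, as compounds 1, 2 and 3 stand only at a limit. Also open, as far as these compounds go, is whether a plain phenyl, pyridin-3-yl or pyrimidin-5-yl would read like compound 4 or like the other three.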